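Fluoro for trifluoromethyl: a cytotoxicity estimate for compound 4

This account rests on a few compounds, and the source may have more. Where it says the series, first, only, none or still open, it means among the compounds named here.

In an ADME assay on Huh-7 cells (Homo sapiens) for cytotoxicity, read by MTT assay, with a stated time of 4 h, at 37 degrees C (on this read-out lower numbers stand for higher toxicity in this test and higher numbers for lower toxicity in this test), compound 1 (`Cn1c(=O)c(-c2c(Br)cccc2Br)cc2c(N)nc(Nc3ccccc3)nc21`) reads 800 nM and compound 2 (`Nc1nc(Nc2ccccc2)nc2[nH]c(=O)c(-c3c(F)cccc3F)cc12`) reads 2400 nM on the same scale. Compound 3 (`Cn1c(=O)c(-c2c(F)cccc2C(F)(F)F)cc2c(N)nc(Nc3ccccc3)nc21`) stands highest of the three with 6300 nM as its number, and its gaps to both of the others lie beyond the scatter. Within the data shown here, it is therefore the least toxic of the measured compounds so far.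

The next compound, compound 4 (`Cn1c(=O)c(-c2c(F)cccc2F)cc2c(N)nc(Nc3ccccc3)nc21`), differs from compound 3 in a single place: fluoro in place of trifluoromethyl on an aromatic carbon with fluoro in place of trifluoromethyl on an aromatic carbon. Among the measured compounds shown here, no pair of measured compounds differs in one place, so nothing yet sizes this change directly. The expectation rests on the spread of values alone, and compound 3 sits at the top of that spread, with compound 2 at 2400 nM as its nearest neighbour. A move back toward the middle therefore seems likelier than a further rise. The expected change is a 2.1-fold lower number from compound 3 to compound 4 (0.32 log units; beyond the scatter) as a modest step toward a lower number. Compound 4 is estimated at 3000 nM with an expected range of 1000 nM to 8000 nM around that figure.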

Compound 4, half-maximal cytotoxic concentration: 10400 nM
Beside the measured number, compound 4's estimate is 3.5-fold (0.54 log units) below it; measured number outside the range, above it.
By their numbers in this assay, from the lowest: compound 1; then compound 2; then compounds 3 and 4 (each within the scatter of the next).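

In this assay, among these compounds, the first comparison that sizes this change directly gives a 1.7-fold higher number from compound 3 to compound 4 (0.22 log units; within the scatter) and so fluoro and trifluoromethyl on this aromatic carbon cannot be told apart here. Two further single-place steps do lie beyond the scatter, with a 4.3-fold higher number from compound 2 to compound 4 (0.64 log units; beyond the scatter) for methyl in place of hydrogen on an aromatic nitrogen and a 13-fold higher number from compound 1 to compound 4 (1.11 log units; beyond the scatter) for 2,6-difluorophenyl in place of 2,6-dibromophenyl on an aromatic carbon, and this last step is the largest of the three. Nothing at hand gives a cause for any of these steps.

Going by these compounds, whether a methoxy or a nitrile on this aromatic carbon would read like fluoro and trifluoromethyl stays open. On these data alone, each change is also seen only once, on a single pair, so whether any of these steps would hold on another background stays open too.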